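The source may report more compounds than this note shows. Statements on the series, on what has been measured and on what is new or still open speak of the compounds shown alone.

Measured so far:
- Compound 1, `CC(=O)Nc1ccc(C2=NN(C)C(=O)CC2)cc1`: only a limit, > 46.4 ug/mL
- Compound 2, `O=C1CCC(c2ccc(NC(=O)CCl)cc2)=NN1`: 0.39 ug/mL

Among the measured compounds shown here, in a functional assay for inhibition, with Homo sapiens as the target (on this read-out lower numbers stand for an effect already at smaller amounts and higher numbers for an effect only at larger amounts of compound), compound 2 gives 0.39 ug/mL, the only plain number in this set. Compound 1 reaches only a limit of this assay, > 46.4 ug/mL (the limit of > 46.4 ug/mL in this assay, at which 1 of the 2 values shown sits). Compound 3, `CN1N=C(c2ccc(NC(=O)CCl)cc2)CCC1=O`, differs from compound 2 in one place: methyl in place of hydrogen on an amide-type nitrogen in a ring. For the measured compounds named here, no step between measured compounds has been followed, so the size of this change is open; a modest loss in this assay, beyond the scatter, seems somewhat likelier than a gain. Compound 3 is expected to give about 1.2 ug/mL, within 0.25 ug/mL to 8 ug/mL, an expected step of a 3.1-fold higher number from compound 2 to compound 3 (0.49 log units; beyond the scatter).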

Compound 3, half-maximal effective concentration: > 46.4 ug/mL
Compound 3: only a limit was reported (the forecaster's own chance of this, stated with the estimate: 15%); middle value at least 38-fold (1.58 log units) from the limit.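

Methyl in place of hydrogen on the amide-type nitrogen in the ring gives, in this assay, an at least 110-fold higher number from compound 2 to compound 3 (2.07 log units; beyond the scatter). A single added carbon at this position is thus enough to take a compound with a plain number to a limit, so the amide hydrogen counts here. Compound 3 now shares the limit of compound 1, and the step between these two cannot be read: the limit of > 46.4 ug/mL in this assay, at which 2 of the 3 values shown sit.

Going by these compounds, the true size of the loss stays open, since only its lower bound is known. On these data alone, whether an ethyl group or a longer chain on this nitrogen would behave the same also stays open.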